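The source may report more compounds than this note shows. Statements on the series, on what has been measured and on what is new or still open speak of the compounds shown alone.

Compound 1 `O=C(Nc1ccc(O)c2c(=O)cc(-c3ccccc3Cl)oc12)c1ccccc1`: 13000 nM
Compound 2 `O=C(Nc1ccc(O)c2c(=O)cc(-c3ccccc3Cl)oc12)c1ccc(Cl)c(Cl)c1`: 13000 nM

In a functional assay on ID8 cells (Mus musculus) for antiproliferative activity (a higher number here means a weaker inhibitor, a lower number a stronger inhibitor), compound 1 gives 13000 nM, and compound 2 gives the same reading, 13000 nM. Compound 3 `COc1ccc(C(=O)Nc2ccc(O)c3c(=O)cc(-c4ccccc4Cl)oc23)cc1` carries one change from compound 1: methoxy in place of hydrogen on an aromatic carbon. This places methoxy in place of hydrogen on an aromatic carbon, para to a large group. Among the compounds with values here, only one measured step touches this phenyl: no change at the digits printed from compound 1 to compound 2 (within the scatter). That single step is thin evidence, but it gives no reason to expect a shift beyond the scatter in this assay. The expected step is no change at the digits printed from compound 1 to compound 3 (within the scatter). For compound 3 the estimated value is 13000 nM, with an expected range from 6000 nM to 28000 nM.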

Compound 3, half-maximal inhibitory concentration: 5000 nM
Compound 3: middle estimate off by 2.6-fold (0.41 log units), on the high side; the measured number lies below the stated range.
By their numbers in this assay, from the lowest: compound 3; then compounds 1 and 2 (each within the scatter of the next).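

On this phenyl ring, the number can move: in this assay, methoxy in place of hydrogen, para to a large group, gives a 2.6-fold lower number from compound 1 to compound 3 (0.41 log units; beyond the scatter) and swapping 3,4-dichlorophenyl for 4-methoxyphenyl gives a 2.6-fold lower number from compound 2 to compound 3 (0.41 log units; beyond the scatter) as well. So not every change on this ring leaves the reading where compound 1 and compound 2 sit. No measurement at hand speaks to what lies behind this step. Still open, as far as these compounds go, is whether the step is particular to methoxy or would also appear with a hydroxyl, an ethoxy or an amine on the same carbon. Also open, from the compounds shown here alone, is whether methoxy on another carbon of this ring would behave alike.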